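The source may report more compounds than this note shows. Statements on the series, on what has been measured and on what is new or still open speak of the compounds shown alone.

Working notes on the nitrobenzamide series, following compound 1 `Cc1cc(NC(=O)c2cc([N+](=O)[O-])ccc2Cl)cc(-c2nc3ccccc3s2)c1O` to compound 4 `O=C(Nc1ccc(O)c(-c2nc3ccccc3s2)c1)c1cc([N+](=O)[O-])ccc1Cl`, with compound 2 `Cc1ccc(-c2nc3ccccc3o2)cc1NC(=O)c1cc([N+](=O)[O-])ccc1Cl` and compound 3 `Cc1ccc(-c2nc3ccccc3s2)cc1NC(=O)c1cc([N+](=O)[O-])c(N2CCCCC2)cc1Cl` as the other members measured.

Among the measured compounds shown here, in an ADME assay for permeability, using PAMPA, at pH 7.4 (a lower number here means that the compound crosses the layer more slowly, a higher number that the compound crosses the layer faster), compound 1 gives 48 10^-6 cm/s, the only full number in the set. For compound 2 this assay returned "below limit of detection" (no number reported), so no number stands for it. Compound 3 sits at a limit of this assay, reported as < 1 10^-6 cm/s; this is the limit of < 1 10^-6 cm/s in this assay, at which 1 of the 3 values shown sits, and not a measured number. For the measured compounds named here, compound 1 therefore stands alone as the measured reference, and no pairwise step has been worked out.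

The change from compound 1 to compound 4 is hydrogen in place of methyl on an aromatic carbon. Going by the values given here, with no measured step to draw on, a step of small size is expected, if anything toward slower crossing, and in any case within the scatter; the step from compound 1 to compound 4 is estimated at a 1.4-fold lower number from compound 1 to compound 4 (0.14 log units; within the scatter). Compound 4 is thus expected to give about 35 10^-6 cm/s, with a range from 15 10^-6 cm/s to 70 10^-6 cm/s.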

Compound 4, apparent permeability: "below limit of detection" (no number reported)
The entry for compound 4 holds no number, and the estimate cannot be compared.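

Compound 4 holds no number in this assay, so no step from compound 1 to compound 4 can be read, and nothing shown bears on this result.

The compounds shown leave open how far hydrogen in place of methyl on this core shifts the read-out in this assay.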